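The source may report more compounds than this note shows. Statements on the series, on what has been measured and on what is new or still open speak of the compounds shown alone.

Measured compounds:
- compound 1, `Cc1ccc(OCC(=O)N(Cc2cccs2)c2ccnn2C)cc1` — 422 nM
- compound 2, `Cc1ccc(OCC(=O)N(Cc2cccs2)C2COC2)cc1` — 23000 nM
- compound 3, `Cc1ccc(OCC(=O)N(Cc2cccs2)c2ccccc2)cc1` — 23 nM

In an assay on HEK293 cells for agonist activity at transient receptor potential cation channel subfamily M member 8 (Homo sapiens), read by fluorescence and calcium flux, with a stated time of 15 min (on this read-out lower numbers stand for an effect already at smaller amounts and higher numbers for an effect only at larger amounts of compound), compound 3 stands lowest of the three numbers; the two steps leading to it, an 18-fold lower number from compound 1 to compound 3 (1.26 log units; beyond the scatter) and a 1000-fold lower number from compound 2 to compound 3 (3.00 log units; beyond the scatter), are both large and well beyond the scatter, and both favour the phenyl over the other groups tried on the amide-type nitrogen. Compound 4, `Cc1ccc(OCC(=O)N(O)Cc2cccs2)cc1`, has not yet been measured. It differs from compound 3 in one place: hydroxy in place of phenyl on an amide-type nitrogen. Since every departure from the phenyl seen so far raised the number sharply, compound 4 is expected to follow the same direction, with an estimated step of a 430-fold higher number from compound 3 to compound 4 (2.64 log units; beyond the scatter). The estimate for compound 4 in this assay is 10000 nM, within a range from 1500 nM to 60000 nM.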

Compound 4, half-maximal effective concentration: 8000 nM
Compound 4: the middle estimate sits 1.3-fold (0.10 log units) above what was measured; measured number inside the range.
By their numbers in this assay, from the lowest: compound 3; then compound 1; then compound 4; then compound 2.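

In this assay, going by these compounds alone, hydroxy is the first group on the amide-type nitrogen with no ring and with a hydrogen-bond donor, and it gives up most of what phenyl offers, with a 350-fold higher number from compound 3 to compound 4 (2.54 log units; beyond the scatter). It also falls behind the pyrazole, with a 19-fold higher number from compound 1 to compound 4 (1.28 log units; beyond the scatter), and gains only modestly on the oxetane, with a 2.9-fold lower number from compound 2 to compound 4 (0.46 log units; beyond the scatter). Across these four compounds, the two aromatic groups give lower numbers than the two non-aromatic ones, and none goes against this.

On these data alone, whether a pyridine ring, a fluorine on the phenyl or a simple methyl on this nitrogen would stay near compound 3 remains open. Nothing shown here gives a cause for these steps.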